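The compounds below may be only part of what the source reports. "The series", "measured", "known", "first", "only" and "open" are said of these compounds alone.

Compound 1 `O=C(NCCCNc1nc(Nc2cnn(C3CC3)c2)ncc1C1CC1)C1CCC1` and compound 2 `O=C(NCCCNc1nc(Nc2cnn(C3CCOCC3)c2)ncc1C1CC1)C1CCC1` share a core with compound 3 `CN1CCN(C(=O)c2ccc(Nc3ncc(C4CC4)c(NCCCNC(=O)C4CCC4)n3)cc2)CC1` and compound 4 `CN1CCC(c2ccc(Nc3ncc(C4CC4)c(NCCCNC(=O)C4CCC4)n3)cc2)CC1`. In an assay on RAW264.7 cells for inhibition of serine/threonine-protein kinase TBK1 (Mus musculus), read by ELISA, with stated times of 30 min and 6 h (on this read-out higher numbers stand for weaker inhibition and lower numbers for stronger inhibition), compound 1 gives 130 nM, and compound 2 gives 280 nM; the step of a 2.2-fold higher number from compound 1 to compound 2 (0.33 log units; beyond the scatter) is modest. In this assay compound 3 is reported as "not active" (no number reported), so no number places it against the other two. Compound 4 differs from compound 3 by 1-methylpiperidin-4-yl in place of (4-methylpiperazin-1-yl)carbonyl on an aromatic carbon. Going by the values given here, no measured step touches this position, and the only step seen, from compound 1 to compound 2, concerns a different part of the molecule, so it gives little guidance. Starting from a compound with no reported number, compound 4 is expected to remain weak, with an estimated value of 3000 nM in this assay, in a range from 500 nM to 20000 nM.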

Compound 4, half-maximal inhibitory concentration: 660 nM
Estimate against measurement, compound 4: 4.5-fold (0.66 log units) above; the range from low to high includes it.
By their numbers in this assay, from the lowest: compound 1; then compound 2; then compound 4.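

Going by these compounds alone, compound 3 has no number in this assay and so no step to compound 4 can be read. The compounds shown leave open how far 1-methylpiperidin-4-yl in place of (4-methylpiperazin-1-yl)carbonyl shifts the read-out. No evidence shown accounts for the result of compound 4.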